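A few compounds are considered here, and "the series" means these few. Any claim that something is new, unique, unknown or untested is made for them only; others in the source may bear on it.

Notes on the series. Among the compounds with values here, compound 1, `O=C(CCCCCc1ccc(Br)cc1)N1CCOC1=O`, in an assay on HEK293 cells for inhibition of N-acylethanolamine-hydrolyzing acid amidase (Rattus norvegicus), read by LC-MS, with a stated time of 30 min (a higher number here means a weaker inhibitor, a lower number a stronger inhibitor), gives 8510 nM, the highest of the two numbers measured so far. Within the data shown here, its nearest neighbour on the numbers is compound 2, `O=C(CCCCCc1cccc(C(F)(F)F)c1)N1CCOC1=O`, which in this assay gives 58 nM; the gap between the two lies beyond the usual scatter, and no single step connects them, so the two values are simply recorded side by side.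

Compound 3, `O=C(CCCCCc1ccc(C(F)(F)F)cc1)N1CCOC1=O`, differs from compound 1 in one place: trifluoromethyl in place of bromo on an aromatic carbon, on an aromatic carbon of the six-membered aromatic ring of carbon only, para to a large group. Among the measured compounds shown here, no measured step of this kind is available. The step of a 5.7-fold lower number from compound 1 to compound 3 (0.75 log units; beyond the scatter) is expected to be a drop of some size, beyond the scatter, toward compound 2, which carries the same entering group and gives 58 nM. For compound 3 a value of 1500 nM is estimated, with a range from 300 nM to 7000 nM.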

Compound 3, half-maximal inhibitory concentration: 1040 nM
For compound 3 the middle estimate is 1.4-fold (0.16 log units) above the measured one; low and high end bracket the measured number.
By their numbers in this assay, from the lowest: compound 2; then compound 3; then compound 1.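

In this assay, trifluoromethyl in place of bromo on an aromatic carbon, para to a large group, goes with an 8.2-fold lower number from compound 1 to compound 3 (0.91 log units; beyond the scatter), the first measured step of this kind in the series. This place on the ring therefore responds to the exchange, but the entering group alone does not reach the lowest number: compound 3 gives 1040 nM, while compound 2, which carries trifluoromethyl at another place on the ring, gives 58 nM. Nothing available accounts for the size of this step.

The compounds shown leave open how fluoro, methoxy or a nitrile would compare with bromo and trifluoromethyl at this same place. Also open, as far as these compounds go, is whether a longer chain in place of the chain of compound 3 would change its number.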